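Propargyl tail in place of the phenoxy tail of compound 1

A few compounds are considered here, and "the series" means these few. Any claim that something is new, unique, unknown or untested is made for them only; others in the source may bear on it.

For the measured compounds named here, compound 1 `O=c1[nH]/c(=N\OCCOc2ccccc2)ccn1[C@@H]1O[C@H](COP(=O)(O)OP(=O)(O)OP(=O)(O)O)[C@@H](O)[C@H]1O` gives 430 nM in a functional assay on 1321-N1 cells for agonist activity at P2Y purinoceptor 4 (Homo sapiens), read by scintillation counting and inositol phosphate accumulation (a higher number here means that more compound is needed for the effect, a lower number that less compound is needed), the highest of the three numbers measured so far. Compound 2 `O=c1[nH]/c(=N\OCCCc2cccnc2)ccn1[C@@H]1O[C@H](COP(=O)(O)OP(=O)(O)OP(=O)(O)O)[C@@H](O)[C@H]1O` gives 300 nM and compound 3 `O=c1[nH]/c(=N\OCCCc2ccncc2)ccn1[C@@H]1O[C@H](COP(=O)(O)OP(=O)(O)OP(=O)(O)O)[C@@H](O)[C@H]1O` gives 250 nM. The steps of a 1.4-fold lower number from compound 1 to compound 2 (0.16 log units; within the scatter) and a 1.7-fold lower number from compound 1 to compound 3 (0.24 log units; within the scatter) are both within the scatter, as is a 1.2-fold lower number from compound 2 to compound 3 (0.08 log units; within the scatter), so exchanging the phenoxy of compound 1 for either pyridinylmethyl leaves the number essentially where it was.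

Compound 4 `C#CCCCO/N=c1/ccn([C@@H]2O[C@H](COP(=O)(O)OP(=O)(O)OP(=O)(O)O)[C@@H](O)[C@H]2O)c(=O)[nH]1` has not yet been measured. It differs from compound 1 by propargyl in place of phenoxy on a saturated chain carbon, two bonds along the chain from an oxygen. Going by the values given here, both measured steps from compound 1 kept a six-membered aromatic ring in the tail; compound 4 keeps no ring, and no measured pair shows what dropping the ring altogether does. The two steps from compound 1 were small, so a step within the scatter is the nearest guide, with some allowance for a higher number given that the change in compound 4 goes further than either measured one. Compound 4 is estimated at 600 nM, with a range from 200 nM to 2000 nM, which means an expected step of a 1.4-fold higher number from compound 1 to compound 4 (0.14 log units; within the scatter).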

Compound 4, half-maximal effective concentration: 410 nM
Compound 4: the middle estimate sits 1.5-fold (0.17 log units) above what was measured, and the stated range covers the measured number.
By their numbers in this assay, from the lowest: compounds 3, 2, 4 and 1 (each within the scatter of the next).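

In this assay, a ring in the tail proves dispensable among these compounds: propargyl in place of phenoxy on a saturated chain carbon, two bonds along the chain from an oxygen, gives a 1.0-fold lower number from compound 1 to compound 4 (0.02 log units; within the scatter). Ethynyl in place of either pyridinyl, on a saturated chain carbon, three bonds along the chain from an oxygen, gives a 1.6-fold higher number from compound 3 to compound 4 (0.21 log units; within the scatter) and a 1.4-fold higher number from compound 2 to compound 4 (0.14 log units; within the scatter), so a tail with no ring sits level with the three ring-bearing tails, and none of the four compounds goes against this. Nothing available explains this tolerance.

All four tails lie within the scatter of one another, so the compounds shown include no change at this position that moves the number. As far as these compounds go, whether an amine, a carboxylic acid or a chain longer than pent-4-yn-1-yl would do so remains open, as does the effect of a plain saturated alkyl tail without the triple bond.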